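The source may hold more compounds than are shown below. What is called first, only, known or untested is meant among the compounds shown, and "the series" means these compounds.

Working notes on the series, read in a functional assay on HepG2 cells (Homo sapiens) for antiproliferative activity, read by MTT assay, with a stated time of 24 h; a higher number here means a weaker inhibitor, a lower number a stronger inhibitor. Compound 1 `COc1cccc(C(=O)Oc2ccc3c(=O)c(-c4cc(OC)c(OC)cc4OC)coc3c2)c1` gives > 10000 nM, which is a limit of the assay. Compound 2 `COc1cc(OC)c(-c2coc3cc(OCC(=O)c4cccc(C(F)(F)F)c4)ccc3c2=O)cc1OC` gives > 10000 nM, again a limit. Among the measured compounds shown here, compound 3 `COc1cc(OC)c(-c2coc3cc(OCc4ccc(F)cc4)ccc3c2=O)cc1OC` gives 1000 nM, the only actual number so far and therefore the sole numerical anchor.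

Compound 4 `COc1cc(OC)c(-c2coc3cc(OCc4ccc([N+](=O)[O-])cc4)ccc3c2=O)cc1OC` differs from compound 3 by a single change, nitro in place of fluoro on an aromatic carbon, para to a large group: nitro in place of fluoro on an aromatic carbon. Cut one bond further out, this reads 4-fluorobenzyl to 4-nitrobenzyl.

Two measured steps reach compound 3: an at least 10-fold lower number from compound 1 to compound 3 (1.00 log units; beyond the scatter), and an at least 10-fold lower number from compound 2 to compound 3 (1.00 log units; beyond the scatter). Both replace a larger part of the group on the oxygen, and both start from the limit of > 10000 nM in this assay, at which 2 of the 3 values shown sit, so their size is open-ended. Neither tests a change at this aromatic carbon alone, so they bear on the step only indirectly, and their size is not carried over.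

With compound 3 at 1000 nM as the starting point, no shift beyond the scatter is expected in this assay, with only a slight lean towards a higher number. The expected change is a 1.5-fold higher number from compound 3 to compound 4 (0.18 log units; within the scatter). For compound 4 the estimated value is 1500 nM, with an expected range from 350 nM to 7000 nM.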

Compound 4, half-maximal inhibitory concentration: 2500 nM
Compound 4: middle estimate off by 1.7-fold (0.22 log units), on the low side; the range from low to high includes it.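

In this assay, the aromatic carbon para to a large group responds to its substituent: a 2.5-fold higher number from compound 3 to compound 4 (0.40 log units; beyond the scatter). This is the first change shown at this carbon alone, and nitro in place of fluoro is a modest loss rather than a silent swap. The 4-nitrobenzyl group still stays clear of the two compounds with a carbonyl in the group on the oxygen, with an at least 4.0-fold lower number from compound 1 to compound 4 (0.60 log units; beyond the scatter) and an at least 4.0-fold lower number from compound 2 to compound 4 (0.60 log units; beyond the scatter), so both benzyl compounds now give actual numbers, but the size of these two steps remains open-ended, as each starts from a limit of the assay: the limit of > 10000 nM in this assay, at which 2 of the 4 values shown sit.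

On these data alone, with only fluoro and nitro at this carbon, two points give no trend, and it remains open whether an amine, a methoxy group or a carboxylic acid there would give a lower number than fluoro or a higher one than nitro. Also open, as far as these compounds go, is whether the 4-fluorobenzyl result holds when a longer chain links the oxygen to the same ring.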